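The source may hold more compounds than are shown below. What is called first, only, known or untested is meant among the compounds shown, and "the series" means these compounds.

Compound 1 `Nc1ccccc1NC(=O)c1ccc(CSC(=S)N2CCN(Cc3ccccn3)CC2)cc1` and compound 2 `Nc1ccccc1NC(=O)c1ccc(CSC(=S)N2CCN(Cc3ccncc3)CC2)cc1` share one core and differ only in the group on the saturated chain carbon bound to the amine nitrogen of the ring. In a functional assay on MGC-803 cells (Homo sapiens) for antiproliferative activity, read by CCK-8 assay, with a stated time of 72 h, tested at 8 uM (on this read-out higher numbers stand for a stronger effect at the one concentration tested and lower numbers for a weaker effect), compound 1 gives 65.2%, and compound 2 gives 79.3%. Among the measured compounds shown here, the single step measured so far is a number 14.1 percentage points higher from compound 1 to compound 2 (beyond the scatter), a change that keeps the heteroaryl ring and moves only its ring nitrogen. On the numbers shown compound 2 stands highest of the two, with compound 1 as its nearest neighbour.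

Compound 3 `Cc1ccc(N2CCN(C(=S)SCc3ccc(C(=O)Nc4ccccc4N)cc3)CC2)cc1` is not yet measured. Its change from compound 2 is 4-methylphenyl in place of (pyridin-4-yl)methyl on an amine nitrogen in a ring. For the measured compounds named here, no measured step bears directly on this change: the one step known swaps one pyridyl for another, whereas here the heteroaryl and its methylene both leave and a carbocyclic aryl sits on the ring nitrogen. The expected step of a number 8.3 percentage points lower from compound 2 to compound 3 (within the scatter) is therefore not expected to exceed the scatter in either direction. Compound 3 is estimated at 71% in this assay, within 50% to 88%.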

Compound 3, a percentage reported as inhibition, at one concentration (the size of the read-out at that concentration, not a potency): 19.8%
Compound 3: middle estimate off by 51.2 percentage points, on the high side; measured number outside the range, below it.
By their numbers in this assay, from the lowest: compound 3; then compound 1; then compound 2.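

In this assay the 4-methylphenyl group in place of (pyridin-4-yl)methyl gives a number 59.5 percentage points lower from compound 2 to compound 3 (beyond the scatter) and in place of (pyridin-2-yl)methyl gives a number 45.4 percentage points lower from compound 1 to compound 3 (beyond the scatter) on the same amine nitrogen in a ring, so the activity depends strongly on which group sits at this position. Both steps are large, while moving the pyridine ring nitrogen gives only a number 14.1 percentage points higher from compound 1 to compound 2 (beyond the scatter) as a modest step, so among these three compounds replacing the whole group on the amine nitrogen matters more than relocating the nitrogen within the pyridine ring. Nothing at hand accounts for the fall in activity.

The change to compound 3 alters three things at once, removing the methylene and the pyridine ring nitrogen and adding the methyl group, and the compounds shown cannot say which of these accounts for the loss. A benzyl group on the same amine nitrogen would keep the methylene with a carbon-only ring, and a pyridin-4-yl group bound directly to that nitrogen would keep the ring nitrogen without the methylene, so these two would begin to separate the contributions.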